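A few compounds are considered here, and "the series" means these few. Any claim that something is new, unique, unknown or untested is made for them only; others in the source may bear on it.

Of the compounds shown here, two have been measured in a functional assay on PC-9 cells (Homo sapiens) for inhibition, read by MTT assay, with a stated time of 48 h, tested at 10 uM; on this read-out lower numbers stand for less inhibition and higher numbers for more inhibition at the one concentration tested (going by the name of the read-out). Compound 1, `Cc1ccc(Nc2cc(NC(=O)Nc3c(Cl)cccc3Cl)ncn2)cc1F`, gives 92% in this assay. Compound 2, `COc1cc(NC(=O)Nc2cc(Nc3ccc(C)c(C)c3)ncn2)cc(OC)c1`, gives 66% in this assay, the lower of the two numbers, with compound 1 standing beyond the usual scatter above it. Compound 2 and compound 1 differ in more than one place, so their gap cannot be tied to a single change.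

Compound 3, `COc1cc(NC(=O)Nc2cc(Nc3ccc(C)c(F)c3)ncn2)cc(OC)c1`, has not yet been measured. It differs from compound 2 by one change: fluoro in place of methyl on an aromatic carbon. The same 3-fluoro-4-methylphenyl group as in compound 3 is carried by compound 1, which gives 92%, but it also differs elsewhere, so this is only a hint. The step from compound 2 to compound 3 is expected to be a modest rise, a number 6 percentage points higher from compound 2 to compound 3 (within the scatter), close to the edge of the scatter. Compound 3 is therefore expected to give about 72% in this assay, within a range from 52% to 88%.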

Compound 3, a percentage reported as inhibition, at one concentration (the size of the read-out at that concentration, not a potency): 77.5%
Beside the measured number, compound 3's estimate is 5.5 percentage points below it; the measured number falls inside the stated range.
By their numbers in this assay, from the lowest: compound 2; then compound 3; then compound 1.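

In this assay, fluoro in place of methyl on this aromatic carbon, ortho to a methyl group, gives a number 11.5 percentage points higher from compound 2 to compound 3 (beyond the scatter). Among the compounds shown here, this is the first pair that differs in one place only, so this gap, unlike the one between compound 1 and compound 2, can be tied to a single change. It shows that this position accepts a swap of one heavy atom for another without losing inhibition, while no measurement here accounts for the rise.

Whether the rise is particular to fluoro stays open, since no other group at this position, such as chloro, methoxy or an amine, appears among these compounds. Also open, on these data alone, is whether the same swap would give a similar step with the other parts of compound 1 in place.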